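A few compounds are considered here, and "the series" means these few. Any claim that something is new, unique, unknown or untested is made for them only; others in the source may bear on it.

Compound 3 `COc1cc(-c2nnc3n2NC(c2ccco2)C(C(=O)c2ccccc2)S3)cc(OC)c1OC` gives 33400 nM in a functional assay on A549 cells (Homo sapiens) for cytotoxicity, read by MTT assay, with a stated time of 48 h (a lower number here means a stronger inhibitor, a higher number a weaker inhibitor), the lowest of the two numbers in hand. Compound 2 `COc1cc(-c2nnc3n2NC(c2cccs2)C(C(=O)c2ccccc2)S3)cc(OC)c1OC` gives 69400 nM in this assay; the measured step is a 2.1-fold lower number from compound 2 to compound 3 (0.32 log units; beyond the scatter). Compound 1 `COc1cc(-c2nnc3n2NC(c2ccco2)C(C(=O)C2CC2)S3)cc(OC)c1OC` gives only a limit in this assay, > 100000 nM. The other measured step, an at least 2.9-fold lower number from compound 1 to compound 3 (0.47 log units; beyond the scatter), rests on that limit of > 100000 nM in this assay, at which 1 of the 3 values shown sits, and is therefore known only as a floor.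

Compound 4 `COc1cc(-c2nnc3n2NC(c2ccco2)C(C(=O)c2cccc(Br)c2)S3)cc(OC)c1OC` is still to be measured in this assay; it differs from compound 3 by bromo in place of hydrogen on an aromatic carbon. Neither measured step touches this place: one exchanges the group on the carbonyl carbon, the other the ring on the saturated ring carbon, and both are modest. Nothing in hand points to a direction for a substituent on the phenyl itself, so the expected step in this assay is a 1.3-fold lower number from compound 3 to compound 4 (0.13 log units; within the scatter), small and close to the scatter. Compound 4 is accordingly estimated at 25000 nM, with a range from 8000 nM to 80000 nM.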

Compound 4, half-maximal inhibitory concentration: 36900 nM
Beside the measured number, compound 4's estimate is 1.5-fold (0.17 log units) below it, within the range that was stated.
By their numbers in this assay, from the lowest: compounds 3, 4 and 2 (each within the scatter of the next, the first and the last beyond it). At a limit, above all of these: compound 1.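

Bromo in place of hydrogen on an aromatic carbon of the phenyl gives a 1.1-fold higher number from compound 3 to compound 4 (0.04 log units; within the scatter) in this assay, the first measured step at this position, and it stays within the scatter. Within the data shown here, in these two compounds, therefore, adding one bromine here leaves the read-out unmoved, while the earlier steps concerned only the group on the carbonyl carbon and the ring on the saturated ring carbon. With 3-bromophenyl in place of cyclopropyl on a carbonyl carbon, the piece shows an at least 2.7-fold lower number from compound 1 to compound 4 (0.43 log units; beyond the scatter), and the size of this step is only a floor, resting on a limit: the limit of > 100000 nM in this assay, at which 1 of the 4 values shown sits.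

As far as these compounds go, whether an amine or a carboxylic acid at this place on the phenyl would move the number stays open. Also open, from the compounds shown here alone, is whether the step between furan-2-yl and thiophen-2-yl holds with 3-bromophenyl on the carbonyl carbon.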